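The compounds below may be only part of what the source reports. "The series", "measured", "known", "first", "only" and "open" are said of these compounds alone.

Measured compounds:
compound 1 `COc1cc(-c2cc(/C=C/C(=O)c3ccc(N)cc3)[nH]n2)cc(OC)c1OC`: 102%
compound 2 `COc1ccc(C(=O)/C=C/c2cc(-c3cc(OC)c(OC)c(OC)c3)n[nH]2)cc1OC`: 71%
compound 3 `COc1ccc(-c2cc(/C=C/C(=O)c3ccc(N)cc3)[nH]n2)cc1OC`: 107%

In a functional assay on TK-10 cells (Homo sapiens) for cytotoxicity, read by sulforhodamine B assay, with a stated time of 48 h, tested at 1 uM (a higher number here means a weaker effect of the compound at the concentration tested, a lower number a stronger effect), compound 3 gives 107% and compound 1 gives 102%. The two differ in one place: methoxy in place of hydrogen on an aromatic carbon. The step is a number 5 percentage points lower from compound 3 to compound 1 (within the scatter). From compound 1 to compound 2 the step is a number 31 percentage points lower from compound 1 to compound 2 (beyond the scatter), and compound 2 stands lowest of the three. The difference between the cores of compound 2 and compound 3 is not broken down here; their two values stand as given.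

Compound 4 `COc1cc(C(=O)/C=C/c2cc(-c3cc(OC)c(OC)c(OC)c3)n[nH]2)cc(OC)c1OC` is not yet measured. It differs from compound 2 as follows: methoxy in place of hydrogen on an aromatic carbon. This is the same change as from compound 3 to compound 1, at a place described in the same words. Because a number 5 percentage points lower from compound 3 to compound 1 (within the scatter) lies within the scatter, the step expected for compound 4 in this assay is a number 5 percentage points lower from compound 2 to compound 4 (within the scatter). Compound 4 is estimated at 66%, expected between 50% and 85%.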

Compound 4, a percentage reported as activity, at one concentration (the size of the read-out at that concentration, not a potency): 80%
Compound 4: the middle estimate sits 14 percentage points below what was measured, within the range that was stated.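

In this assay, methoxy in place of hydrogen on an aromatic carbon gives a step of a number 9 percentage points higher from compound 2 to compound 4 (within the scatter). Set beside the earlier step on the other core, the change reads alike on both: the same change on two cores in this assay, a number 5 percentage points lower (within the scatter) from compound 3 to compound 1 and a number 9 percentage points higher (within the scatter) from compound 2 to compound 4, 14 percentage points apart, within the scatter of two such steps. Within the data shown here, this shows that on these two cores the change gives no step beyond the scatter, but it rests on only two pairs and does not show that the same would hold on a further core, nor does it explain the result.

The compounds shown leave open whether a hydroxyl group, an amine or a longer chain such as ethoxy at the same place would give a step beyond the scatter. They also leave open how such a group would read on each of the two cores.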